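This account rests on a few compounds, and the source may have more. Where it says the series, first, only, none or still open, it means among the compounds named here.

Working notes on the series. Compound 1 `CCCCOc1ccc(NC(=O)n2nc(N)c3ccccc32)cc1` carries a butoxy group on the aryl amide side of the shared core. Going by the values given here, in a functional assay on K562 cells (Homo sapiens) for inhibition, read by sulforhodamine B assay, with a stated time of 48 h (a lower number here means a stronger inhibitor of growth, a higher number a weaker inhibitor of growth), compound 1 gives 15900 nM, which is the only numerical value in the set so far. Compound 2 `Nc1nn(C(=O)Nc2c(F)cccc2F)c2ccccc12` carries a different aryl group. In this assay compound 2 gives < 100000 nM, which is a limit of the assay and not a number. Compound 2 thus sits at the limit of < 100000 nM in this assay, at which 1 of the 2 values shown sits. Among the compounds with values here, no step between two measured compounds is available, so nothing yet shows how large a change in this assay a single substitution produces.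

Compound 3 `Nc1nn(C(=O)Nc2ccc(Cc3ccccc3)cc2)c2ccccc12` differs from compound 1 in one place: benzyl in place of butoxy on an aromatic carbon. Within the data shown here, with no measured step to lean on, the expected step from butoxy to benzyl in this assay is none beyond the usual scatter, with no clear direction. The estimated step of a 1.4-fold lower number from compound 1 to compound 3 (0.16 log units; within the scatter) is therefore expected to be small. For compound 3 the estimate in this assay is 11000 nM, within an expected range from 3000 nM to 40000 nM.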

Compound 3, concentration for 50% growth inhibition: 1200 nM
Compound 3: the middle estimate sits 9.2-fold (0.96 log units) above what was measured; the measured number lies below the stated range.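

Going by these compounds alone, this is the first measured step, and it shows that the aromatic carbon para to a large group is not indifferent to what it carries: in this assay, benzyl in place of butoxy gives a large change (a 13-fold lower number from compound 1 to compound 3 (1.12 log units; beyond the scatter)). The step lies beyond the scatter and points towards stronger inhibition of growth, so a single substitution at this place can move the read-out substantially. The data shown give no basis for explaining why this change has this size.

The change swaps a chain holding an oxygen for a group holding a six-membered aromatic ring of carbon only, so the compounds shown leave open whether the ring, the loss of the oxygen or the added heavy atoms accounts for the step. A phenoxy group or a plain pentyl chain on the same carbon would begin to separate these, and a morpholine or a carboxylic acid there would show whether the trend extends beyond neutral groups.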